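Expectation for compound 3 from the amine chain step

The compounds below may be only part of what the source reports. "The series", "measured", "known", "first", "only" and "open" are said of these compounds alone.

In a functional assay on HCT-116 cells (Homo sapiens) for antiproliferative activity, read by WST assay, with a stated time of 72 h (on this read-out lower numbers stand for an effect already at smaller amounts and higher numbers for an effect only at larger amounts of compound), compound 2 `CCCCNCCCC(=O)Nc1ccc(/C(N)=N/O)cc1` gives 267000 nM and compound 1 `CCCCCCNCCCC(=O)Nc1ccc(/C(N)=N/O)cc1` gives 312000 nM, two values within the scatter of each other. Compound 3 `CCCCCCNCCCCC(=O)Nc1ccc(/C(N)=N/O)cc1` differs from compound 2 by (hexylamino)methyl in place of butylamino on a saturated chain carbon, three bonds along the chain from a carbonyl carbon. Among the compounds with values here, one measured step bears on this, a 1.2-fold lower number from compound 1 to compound 2 (0.07 log units; within the scatter), with hydrogen in place of ethyl on a saturated chain carbon, four bonds along the chain from an amine nitrogen. Within the data shown here, it covers only part of the change, and no measured step covers the carbon added on the carbonyl side. The expected change in this assay is therefore none beyond the scatter, with no firm direction. The estimated step is a 1.1-fold higher number from compound 2 to compound 3 (0.04 log units; within the scatter). For compound 3 the expected value is 290000 nM, with an estimated range of 130000 nM to 600000 nM.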

Compound 3, half-maximal effective concentration: > 1000000 nM
Compound 3: only a limit was reported; the forecaster's own chance of this, stated with the estimate: 20%; middle value at least 3.4-fold (0.53 log units) away from the limit.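

In this assay, (hexylamino)methyl in place of butylamino on a saturated chain carbon, three bonds along the chain from a carbonyl carbon, gives an at least 3.7-fold higher number from compound 2 to compound 3 (0.57 log units; beyond the scatter), and (hexylamino)methyl in place of hexylamino on that carbon gives an at least 3.2-fold higher number from compound 1 to compound 3 (0.50 log units; beyond the scatter). Compound 1 and compound 3 share the hexylamino end, so the carbon added on the carbonyl side moves the read-out beyond the scatter, whereas the amine chain step, a 1.2-fold lower number from compound 1 to compound 2 (0.07 log units; within the scatter), did not. Compound 3 has only a limit, not a number, so both steps give a minimum size: the limit of > 1000000 nM in this assay, at which 1 of the 3 values shown sits.

From the compounds shown here alone, whether butylamino on this longer chain also reaches a limit remains open. Also open, going by these compounds, is whether a shorter chain on the carbonyl side, or a carboxylic acid in place of the amine, would shift the read-out.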